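A few compounds are considered here, and "the series" means these few. Any claim that something is new, unique, unknown or untested is made for them only; others in the source may bear on it.

Measured so far in a functional assay on PC-12 cells (Rattus norvegicus) for cytotoxicity, read by MTT assay, with stated times of 2 h and 24 h, tested at 5 uM; a lower number here means a weaker effect, a higher number a stronger effect of the compound at the concentration tested:
compound 1 `CC(C)c1ccc(-n2nc(-c3ccc(C(F)(F)F)cc3O)nc2-c2ccccc2O)cc1` gives 100%;
compound 2 `CC(C)(C)c1ccc(-n2nc(-c3ccc(C(F)(F)F)cc3O)nc2-c2ccccc2O)cc1` gives 77.8%;
compound 3 `COc1ccc(-n2nc(-c3ccc(C(F)(F)F)cc3O)nc2-c2ccccc2O)cc1` gives 86.6%.

Within this set, compound 3 stands second highest of the three numbers. Its nearest neighbour is compound 2, and that gap, a number 8.8 percentage points higher from compound 2 to compound 3 (within the scatter), is within the scatter, so no order between compound 2 and compound 3 can be read from it. The furthest is compound 1, and the step of a number 13.4 percentage points lower from compound 1 to compound 3 (beyond the scatter) is beyond the scatter.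

Compound 4 `Oc1cc(C(F)(F)F)ccc1-c1nc(-c2ccccc2O)n(-c2ccccc2C(F)(F)F)n1` is not yet measured. The change from compound 3 is 2-(trifluoromethyl)phenyl in place of 4-methoxyphenyl on an aromatic nitrogen. All three measured steps alter the group carried on the same aromatic nitrogen, so all of them bear on this step: a number 22.2 percentage points lower from compound 1 to compound 2 (beyond the scatter), a number 13.4 percentage points lower from compound 1 to compound 3 (beyond the scatter) and a number 8.8 percentage points higher from compound 2 to compound 3 (within the scatter). Going by the values given here, the two steps that exceed the scatter are modest in size, and none of the measured compounds carries a 2-(trifluoromethyl)phenyl there, so the direction of the step cannot be read from a matching precedent. The range of the three measured values suggests that swapping the aryl group on this nitrogen moves the read-out by a modest amount at most.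

For compound 4 the expectation is therefore a value close to that of compound 3, with a step of about a number 2.6 percentage points lower from compound 3 to compound 4 (within the scatter), estimated at 84% within a range from 62% to 100%.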

Compound 4, a percentage reported as activity, at one concentration (the size of the read-out at that concentration, not a potency): 80%
Estimate against measurement, compound 4: 4 percentage points above; low and high end bracket the measured number.
By their numbers in this assay, from the lowest: compounds 2, 4 and 3 (each within the scatter of the next); then compound 1.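

In this assay, going by these compounds alone, a phenyl group on the aromatic nitrogen that carries trifluoromethyl and no oxygen or alkyl group still falls in the same band as the earlier compounds: a number 6.6 percentage points lower from compound 3 to compound 4 (within the scatter) and a number 2.2 percentage points higher from compound 2 to compound 4 (within the scatter) leave compound 4 inseparable from compound 3 and compound 2. Within the data shown here, only compound 1 stands apart, with a number 20 percentage points lower from compound 1 to compound 4 (beyond the scatter) now joining a number 22.2 percentage points lower from compound 1 to compound 2 (beyond the scatter) and a number 13.4 percentage points lower from compound 1 to compound 3 (beyond the scatter), so 4-isopropylphenyl is the one group here whose number is separated from all the others, while 4-(tert-butyl)phenyl, 4-methoxyphenyl and 2-(trifluoromethyl)phenyl show no order among themselves. No measurement is available that explains this separation or the lack of order among the other three.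

These compounds do not separate the effect of the trifluoromethyl group from the effect of where it sits on the phenyl ring, since the substituent and its place differ together in each step to compound 4. Also open, from the compounds shown here alone, is how the read-out in this assay responds to an amine or a carboxylic acid on that phenyl ring, or to a longer alkyl chain in place of the phenyl ring on the same nitrogen.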